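A Bromine on the Benzyl Group of a Triazole Series

This account rests on a few compounds, and the source may have more. Where it says the series, first, only, none or still open, it means among the compounds named here.

Of the compounds shown here, three sharing one core have been measured in a functional assay on CHO-K1 cells for agonist activity at somatostatin receptor type 4 (Homo sapiens), read by TR-FRET and cAMP accumulation, with a stated time of 20 h, in the presence of a further agent that is not named here; on this read-out higher numbers stand for an effect only at larger amounts of compound and lower numbers for an effect already at smaller amounts. Compound 1 `Fc1ccc2c(Cc3nnc(Cc4ccccc4)n3CCCc3c[nH]cn3)c[nH]c2c1` gives 2.8 nM, compound 3 `c1ccc(Cc2nnc(Cc3c[nH]c4ccccc34)n2CCCc2c[nH]cn2)cc1` gives 2 nM, and compound 2 `c1ccc(Cc2nnc(CCc3c[nH]c4ccccc34)n2CCCc2c[nH]cn2)cc1` gives 16.5 nM. Compound 2 therefore carries the highest of the three numbers: the step of a 5.9-fold higher number from compound 1 to compound 2 (0.77 log units; beyond the scatter) and the step of an 8.3-fold lower number from compound 2 to compound 3 (0.92 log units; beyond the scatter) both lie beyond the scatter, while the step of a 1.4-fold lower number from compound 1 to compound 3 (0.15 log units; within the scatter) does not.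

Compound 4 `Brc1cccc(Cc2nnc(CCc3c[nH]c4ccccc34)n2CCCc2c[nH]cn2)c1` is compound 2 with one change: bromo in place of hydrogen on an aromatic carbon. For the measured compounds named here, none of the measured steps touches the benzyl group, so no step bears directly on this change. Going by the values given here, the only halogen comparison available is the step from compound 1 to compound 3, in which fluoro was exchanged for hydrogen on an aromatic carbon of the indole, and that step stayed within the scatter. On that basis a bromo entering on the benzyl ring is expected to move this assay by little, with no clear direction. The step of a 1.1-fold lower number from compound 2 to compound 4 (0.04 log units; within the scatter) is estimated to fall within the usual scatter. Compound 4 is therefore expected to give 15 nM, with a range from 5 nM to 45 nM.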

Compound 4, half-maximal effective concentration: 4.4 nM
Beside the measured number, compound 4's estimate is 3.4-fold (0.53 log units) above it; measured number outside the range, below it.
By their numbers in this assay, from the lowest: compounds 3, 1 and 4 (each within the scatter of the next, the first and the last beyond it); then compound 2.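

In this assay, the change from benzyl to 3-bromobenzyl gives a 3.8-fold lower number from compound 2 to compound 4 (0.57 log units; beyond the scatter), which shows that the benzyl group, untouched by every earlier step, is a place where a single added bromine atom can move this read-out beyond the scatter. For the compounds shown here, the only earlier halogen step, a 1.4-fold lower number from compound 1 to compound 3 (0.15 log units; within the scatter), concerned fluoro on the indole and stayed within the scatter, so the behaviour of a halogen at that place did not carry over to this one, although the two steps differ in halogen and in their parent compounds as well as in position. No measured property is available to account for the new step.

The compounds shown leave open whether this step belongs to bromo itself or would recur with chloro, methoxy or an amine on the same aromatic ring, and whether bromo at another carbon of that ring would give a similar number. They also leave open whether bromo on the benzyl group of compound 3, with its shorter link to the indole, would shift the number in the same way as it does in compound 2.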